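A few compounds are considered here, and "the series" means these few. Any claim that something is new, unique, unknown or untested is made for them only; others in the source may bear on it.

Among the measured compounds shown here, compound 1 `C=CC1=C(C(=O)NCCCCC)C(c2ccc(OC)cc2)OC1` is the only compound here with a measured number: in a functional assay on A549 cells (Homo sapiens) for cytotoxicity, read by MTT assay, with a stated time of 24 h (on this read-out lower numbers stand for stronger inhibition and higher numbers for weaker inhibition), compound 1 gives 36500 nM. Compound 2 `C=CC1=C(C(=O)NCCCCC)C(c2ccc(F)cc2)OC1` reaches only a limit of this assay, > 100000 nM, and not a number. Compound 3 `C=CC1=C(C(=O)NCCCCC)C(c2ccc(Cl)c(Cl)c2)OC1` likewise reaches only a limit, > 100000 nM. For the measured compounds named here, the one step between measured compounds, an at least 2.7-fold higher number from compound 1 to compound 2 (0.43 log units; beyond the scatter), weakens inhibition, and both limits are the same one: the limit of > 100000 nM in this assay, at which 2 of the 3 values shown sit.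

Compound 4 `C=CC1=C(C(=O)Nc2ccc(OCC)cc2)C(c2ccc(OC)cc2)OC1` differs from compound 1 at another place entirely: 4-ethoxyphenyl in place of pentyl on an amide-type nitrogen. Going by the values given here, no measured step touches the amide-type nitrogen; the single step known changes a group on an aromatic carbon and gives no guide here. With nothing to point either way, the expectation is a step of no clear direction, and compound 4 is estimated at 36500 nM, within a range from 12000 nM to 100000 nM. That estimate means an expected step of no change at the digits printed from compound 1 to compound 4 (within the scatter), staying within the scatter.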

Compound 4, half-maximal inhibitory concentration: 17600 nM
Estimate against measurement, compound 4: 2.1-fold (0.32 log units) above; the measured number falls inside the stated range.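

Among the compounds shown here, the amide-type nitrogen, which no earlier step touched, turns out to matter in this assay: putting 4-ethoxyphenyl there in place of pentyl gives a 2.1-fold lower number from compound 1 to compound 4 (0.32 log units; beyond the scatter), a modest gain in inhibition. So this position accepts a group with a six-membered aromatic ring and a hydrogen-bond acceptor, where the earlier compounds offered only a flexible pentyl chain as a guide. Compound 4 also adds a second true number to a small set in which much of the data stops at a limit: the limit of > 100000 nM in this assay, at which 2 of the 4 values shown sit.

A plain phenyl or a benzyl group on the same nitrogen would help show whether the aromatic ring or the ethoxy oxygen goes with this gain. Also open, on these data alone, is how an amine or a carboxylic acid would fare at this nitrogen, and whether 4-ethoxyphenyl would give a measurable number on compound 2.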